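Halogen Swap on the Anilino Ring of an Acrylamide Series

The source may hold more compounds than are shown below. What is called first, only, known or untested is meant among the compounds shown, and "the series" means these compounds.

Three measured compounds share one core and differ only in the anilino ring. Compound 1 `C=CC(=O)Nc1cccc(NC(=O)CSc2nc(Nc3ccccc3Cl)c3ccccc3n2)c1` gives 14400 nM in a functional assay on PC-3 cells (Homo sapiens) for inhibition, read by MTT assay, with a stated time of 72 h; a lower number here means a stronger inhibitor, a higher number a weaker inhibitor. Compound 2 `C=CC(=O)Nc1cccc(NC(=O)CSc2nc(Nc3ccccc3Br)c3ccccc3n2)c1` gives 17100 nM in this assay, and compound 3 `C=CC(=O)Nc1cccc(NC(=O)CSc2nc(Nc3ccc(Cl)cc3)c3ccccc3n2)c1` gives 10800 nM. Compound 3 differs from compound 1 by 4-chlorophenyl in place of 2-chlorophenyl on a nitrogen on an aromatic ring. The change bromo in place of chloro on an aromatic carbon gave a 1.2-fold higher number from compound 1 to compound 2 (0.07 log units; within the scatter). Compound 4 `C=CC(=O)Nc1cccc(NC(=O)CSc2nc(Nc3ccc(Br)cc3)c3ccccc3n2)c1` is not yet measured; it carries the same kind of change, (bromo in place of chloro on an aromatic carbon), but here the bromo sits para to a large group rather than ortho to a large group. Because a 1.2-fold higher number from compound 1 to compound 2 (0.07 log units; within the scatter) lies within the scatter, the step of a 1.2-fold higher number from compound 3 to compound 4 (0.06 log units; within the scatter) is expected to be small. Compound 4 is therefore estimated at 12500 nM, between 6000 nM and 26000 nM.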

Compound 4, half-maximal inhibitory concentration: 12400 nM
The estimate for compound 4 lay 1.0-fold (0.00 log units) above the measured number, within the range that was stated.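

In this assay, bromo in place of chloro on the 4-chlorophenyl ring gave a 1.1-fold higher number from compound 3 to compound 4 (0.06 log units; within the scatter), and this step agrees with the earlier one: the same change on two cores in this assay, a 1.2-fold higher number (0.07 log units; within the scatter) from compound 1 to compound 2 and a 1.1-fold higher number (0.06 log units; within the scatter) from compound 3 to compound 4, 1.0-fold (0.01 log units) apart, within the scatter of two such steps. The other new steps, a 1.4-fold lower number from compound 2 to compound 4 (0.14 log units; within the scatter) and a 1.2-fold lower number from compound 1 to compound 4 (0.06 log units; within the scatter), also lie within the scatter. Steps this small show only that the swap made no readable difference on either core; they do not show that any effect of the halogen carries from one core to another, or that it would stay this small on a different core.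

The compounds shown leave open whether a methoxy group or an amine on the anilino ring would move the number beyond the scatter. They also leave open what a saturated propanamide in place of the acrylamide would do.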